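A few compounds are considered here, and "the series" means these few. Any claim that something is new, unique, unknown or untested is made for them only; others in the source may bear on it.

Compounds 1, 2 and 3 share one core, seen in compound 1 `O=C1CCc2cc(-n3cnnc3)ccc2N1Cc1ccccc1F`, compound 2 `O=C1CCc2cc(-n3cnnc3)ccc2N1Cc1ccccc1Cl` and compound 3 `O=C1CCc2cc(-n3cnnc3)ccc2N1Cc1ccc(Cl)cc1Cl`. In a functional assay on the whole organism (strain KunMing) with Mus musculus as the target, in the maximal electroshock model, with a stated time of 4 h (on this read-out higher numbers stand for an effect only at larger amounts of compound and lower numbers for an effect already at smaller amounts), compound 1 gives 300 mg/kg. Compound 2 gives 300 mg/kg. Compound 3 gives 300 mg/kg, level with both. The three steps among them, no change at the digits printed from compound 1 to compound 2 (within the scatter), no change at the digits printed from compound 1 to compound 3 (within the scatter) and no change at the digits printed from compound 2 to compound 3 (within the scatter), all stayed within the scatter. Compound 4 `O=C1CCc2cc(-n3cnnc3)ccc2N1Cc1cccc(Cl)c1` differs from compound 3 by 3-chlorophenyl in place of 2,4-dichlorophenyl on a saturated chain carbon bound to an amide-type nitrogen in a ring. Of the measured steps, no change at the digits printed from compound 1 to compound 3 (within the scatter) bears most closely on this change, exchanging one substituted phenyl for another at the same place, and it brought nothing beyond the scatter. Compound 4 is therefore expected to show no step beyond the scatter, no change at the digits printed from compound 3 to compound 4 (within the scatter). The value of compound 4 in this assay is estimated at 300 mg/kg, within the range 150 mg/kg to 600 mg/kg.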

Compound 4, minimum effective dose: 300 mg/kg
The estimate for compound 4 equals the measured number at the digits printed; the range from low to high includes it.
By their numbers in this assay, from the lowest: compounds 1, 2, 3 and 4 (each within the scatter of the next).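

In this assay the 3-chlorophenyl of compound 4 adds a further substituted phenyl on a saturated chain carbon bound to an amide-type nitrogen in a ring, and the exchange gives no change at the digits printed from compound 3 to compound 4 (within the scatter) together with no change at the digits printed from compound 2 to compound 4 (within the scatter) and no change at the digits printed from compound 1 to compound 4 (within the scatter) at this place. All four substituted phenyl groups shown therefore read alike here, so the place has not yet told any of them apart. No evidence on why this reading stays level is available.

Open, from the compounds shown here alone, is whether a group of another kind at this place, such as an amine, a carboxylic acid or a longer chain without the phenyl, would move the reading. Also open, going by these compounds, is whether any change to the shared core itself would do so.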